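The source may report more compounds than this note shows. Statements on the series, on what has been measured and on what is new or still open speak of the compounds shown alone.

Of the compounds shown here, three have so far been measured in a functional assay on U-87MG ATCC cells for antiproliferative activity against U-87 MG (Homo sapiens), read by MTT assay, with a stated time of 48 h, tested at 50 uM; on this read-out higher numbers stand for a weaker effect at the one concentration tested and lower numbers for a stronger effect. Compound 1 `COc1ccc(-c2nc(C)c(C(=O)CSc3nc(N)c(C#N)c(-c4ccc(Cl)cc4)n3)s2)cc1` gives 23.1%. Compound 2 `COc1ccc(-c2nc(C)c(C(=O)CSc3nc(N)c(C#N)c(-c4ccccc4)n3)s2)cc1` gives 16.5%. These two differ only by chloro in place of hydrogen on an aromatic carbon, and that change made a number 6.6 percentage points higher from compound 2 to compound 1 (within the scatter). Compound 3 `Cc1nc(-c2ccccc2)sc1C(=O)CSc1nc(-c2ccc(Cl)cc2)c(C#N)c(=O)[nH]1` rests on another core and gives 63.4%; how its core differs from the core of compound 2 is not broken down here. Compound 4 `Cc1nc(-c2ccc(Cl)cc2)sc1C(=O)CSc1nc(-c2ccc(Cl)cc2)c(C#N)c(=O)[nH]1` has not been measured. Within the data shown here, it differs from compound 3 by chloro in place of hydrogen on an aromatic carbon, the same change in the same place as the one that turned compound 2 into compound 1. Because that earlier change gave a number 6.6 percentage points higher from compound 2 to compound 1 (within the scatter), a similarly small step is expected here, a number 4.6 percentage points higher from compound 3 to compound 4 (within the scatter). Compound 4 is accordingly estimated at 68%, with a range from 52% to 84%.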

Compound 4, a percentage reported as activity, at one concentration (the size of the read-out at that concentration, not a potency): 60%
Estimate against measurement, compound 4: 8 percentage points above; measured number inside the range.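

In this assay, chloro in place of hydrogen gives a number 3.4 percentage points lower from compound 3 to compound 4 (within the scatter), so this step is too small to tell apart from repeat-to-repeat variation. The earlier step points the same way, and the two do not differ: the same change on two cores in this assay, a number 6.6 percentage points higher (within the scatter) from compound 2 to compound 1 and a number 3.4 percentage points lower (within the scatter) from compound 3 to compound 4, 10 percentage points apart, within the scatter of two such steps. This shows that the change had no readable effect on either of these two cores, but two pairs at a single concentration show neither that this holds on other cores nor anything about potency.

The compounds shown leave open whether a larger step would appear with a different group in place of the chloro, such as an amine or a carboxylic acid. From the compounds shown here alone, whether fluoro would behave like chloro also remains open.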